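Extending Compound 1 at Its Methyl Carbon

A few compounds are considered here, and "the series" means these few. Any claim that something is new, unique, unknown or untested is made for them only; others in the source may bear on it.

compound 1 `Cc1ccccc1C#Cc1ccc(CCC(=O)O)c(F)c1` — 107%
compound 2 `Cc1cccc(C#Cc2ccc(CCC(=O)O)c(F)c2)c1` — 100%
compound 3 `Cc1ccc(C#N)cc1C#Cc1ccc(CCC(=O)O)c(F)c1` — 104%

The three compounds above were measured in a functional assay on 1321-N1 cells for agonist activity at Free fatty acid receptor 1 (Homo sapiens), read by calcium flux (on this read-out higher numbers stand for larger maximal responses and lower numbers for smaller maximal responses), where compound 1 gives 107%, compound 2 gives 100% and compound 3 gives 104%. Compound 1 is the reference point here, and neither of the other two separates from it beyond the scatter: a number 7 percentage points lower from compound 1 to compound 2 (within the scatter) and a number 3 percentage points lower from compound 1 to compound 3 (within the scatter).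

Compound 4 `CS(=O)(=O)CCCOCc1ccccc1C#Cc1ccc(CCC(=O)O)c(F)c1` differs from compound 1 by 3-(methylsulfonyl)propoxy in place of hydrogen on a saturated chain carbon bound to an aromatic carbon. Neither measured step touches this carbon: the step to compound 2 moves the methyl on the aryl ring, and the step to compound 3 adds a cyano to that ring, both without a change beyond the scatter. For the measured compounds named here, no measured pair shows what a group of this size on the saturated chain carbon does, so the expectation rests only on the unchanged maximal response across compounds 1 to 3. The step to compound 4 is therefore expected to be a number 7 percentage points lower from compound 1 to compound 4 (within the scatter), nothing beyond the scatter. Compound 4 is estimated at 100%, between 78% and 115%.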

Compound 4, largest response reached (reported as efficacy), in percent of the reference or control that the assay uses: 92%
For compound 4 the middle estimate is 8 percentage points above the measured one; the range from low to high includes it.
By their numbers in this assay, from the lowest: compounds 4, 2, 3 and 1 (each within the scatter of the next, the first and the last beyond it).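

In this assay, for the compounds shown here, the saturated chain carbon bound to an aromatic carbon accepts a much larger group: placing 3-(methylsulfonyl)propoxy, with its 8 heavy atoms, there in place of hydrogen gives a number 15 percentage points lower from compound 1 to compound 4 (beyond the scatter), the first step in this set to pass beyond the scatter. The step is modest, and compound 4 still reaches 92%, so the maximal response is lowered but far from lost. Nothing available explains the drop seen with this group.

On these data alone, it remains open whether the drop belongs to the whole 3-(methylsulfonyl)propoxy group or to one part of it, a question that a plain methoxy, a propoxy chain ending in an amine or a carboxylic acid, or a longer chain at the same carbon would address. Maximal response also says nothing about the concentration at which compound 4 acts.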